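The compounds below may be only part of what the source reports. "The series", "measured", "known", "first", "only" and "open" are said of these compounds alone.

In a functional assay on HeLa cells (Homo sapiens) for cytotoxicity, read by CCK-8 assay (on this read-out higher numbers stand for weaker inhibition and lower numbers for stronger inhibition), compound 1 `O=C(Nc1ccc(O)cc1)c1ncc(-c2ccccc2)o1` gives 780 nM. Compound 2 `Cc1ccc(NC(=O)c2ncc(-c3ccccc3)o2)cc1` gives > 30000 nM, which is a limit of the assay and not a number. Compound 3 `CCN(CC)c1ccc(NC(=O)c2ncc(-c3ccccc3)o2)cc1` differs from compound 2 in one place, with diethylamino in place of methyl on an aromatic carbon. Among the compounds with values here, only one measured step bears on this change. With methyl in place of hydroxy, the read-out shows an at least 38-fold higher number from compound 1 to compound 2 (1.58 log units; beyond the scatter), a large step beyond the scatter. That step shows that the group on this carbon can matter greatly, yet neither compound carries diethylamino, so its guidance is limited. A moderate move towards a lower number in this assay is expected, although compound 3 may also remain at the limit. The expected change is an at least 3.7-fold lower number from compound 2 to compound 3 (0.57 log units; beyond the scatter). Compound 3 is estimated at 8000 nM, with an expected range of 1500 nM to 30000 nM.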

Compound 3, half-maximal inhibitory concentration: > 30000 nM
Compound 3 gave a limit, no number (the forecaster's own chance of this, stated with the estimate: 35%); middle value at least 3.7-fold (0.57 log units) from the limit.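

In this assay compound 3 gives > 30000 nM, which is a limit of the assay and not a number. Replacing the hydroxy group with diethylamino, a group of 5 heavy atoms, gives an at least 38-fold higher number from compound 1 to compound 3 (1.58 log units; beyond the scatter), so a second replacement on this carbon also leaves the compound far from compound 1, and the large step is not tied to methyl alone. The step between the two compounds without hydroxy cannot be read, because neither has a number to compare: the limit of > 30000 nM in this assay, at which 2 of the 3 values shown sit.

On these data alone, what remains open is whether the hydroxy group itself is needed or whether other groups on this carbon could also give a measurable number. A methoxy group or an unsubstituted amino group in its place would bear on that question.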